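A few compounds are considered here, and "the series" means these few. Any claim that something is new, unique, unknown or untested is made for them only; others in the source may bear on it.

Measured compounds:
- compound 1, `CC(=O)Nc1cc(NC(=O)Nc2ccc(Cl)nc2)ccc1C`: 1100 nM
- compound 2, `Cc1ccc(NC(=O)Nc2cccc(Oc3ccccc3)c2)cc1NC(=O)c1ccccc1`: > 30000 nM

Among the measured compounds shown here, in a functional assay on A375P cells (Homo sapiens) for antiproliferative activity (on this read-out higher numbers stand for weaker inhibition and lower numbers for stronger inhibition), compound 1 gives 1100 nM and this is the only number among the values shown. For compound 2 this assay reports only a limit, > 30000 nM. Of the two values shown, one sits at the limit of > 30000 nM in this assay, at which 1 of the 2 values shown sits. The unmeasured compound 3, `Cc1ccc(NC(=O)Nc2ccc(Cl)nc2)cc1NC(=O)c1ccccc1`, differs from compound 1 in one place: phenyl in place of methyl on a carbonyl carbon, so that acetamido becomes benzamido while the shared core and the chloropyridyl urea remain. For the measured compounds named here, no measured pair follows this single change, and compound 2 carries the benzamido group together with a different urea partner, so it cannot settle the step by itself. He expects a step from compound 1 to compound 3 of a 2.3-fold higher number from compound 1 to compound 3 (0.36 log units; beyond the scatter) in this assay, a modest weakening. Compound 3 is therefore estimated at 2500 nM, within 600 nM to 12000 nM.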

Compound 3, half-maximal inhibitory concentration: 1600 nM
Compound 3: the middle estimate sits 1.6-fold (0.19 log units) above what was measured, and the stated range covers the measured number.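

In this assay, phenyl in place of methyl on a carbonyl carbon, which turns acetamido into benzamido, gives a 1.5-fold higher number from compound 1 to compound 3 (0.16 log units; within the scatter) and so leaves the read-out within the scatter at this position. Compound 2, which also carries benzamido, has only a limit in this assay of > 30000 nM and this is a limit of the assay, not a number. Benzamido alone therefore does not bring compound 3 to such a limit, and nothing shown gives a cause for the step.

As far as these compounds go, whether this position also tolerates a longer chain, or a carbonyl carbon bearing an amine, remains open. From the compounds shown here alone, how much the urea partner matters is also open, since only the chloropyridyl and phenoxyphenyl forms appear here.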